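The source may hold more compounds than are shown below. What is called first, only, known or untested is meant among the compounds shown, and "the series" means these compounds.

Three esters sharing one core have been tested in a functional assay on OVCAR-5 cells (Homo sapiens) for inhibition, with a stated time of 48 h, tested at 50 uM; on this read-out lower numbers stand for less inhibition of growth and higher numbers for more inhibition of growth at the one concentration tested: compound 1 (`C=C[C@@](C)(/C=C/c1ccc(OC(=O)CC)cc1)CCC=C(C)C`) gives 52%, compound 2 (`C=C[C@@](C)(/C=C/c1ccc(OC(=O)CCCC)cc1)CCC=C(C)C`) gives 3% and compound 3 (`C=C[C@@](C)(/C=C/c1ccc(OC(=O)CCCCCCC)cc1)CCC=C(C)C`) gives 42%. That third value belongs to the upper pair of the set, with a number 10 percentage points lower from compound 1 to compound 3 (within the scatter). Compound 4 (`C=C[C@@](C)(/C=C/c1ccc(OC(=O)CCCCCCCCC)cc1)CCC=C(C)C`) is the next case, and the change is ethyl in place of hydrogen on a saturated chain carbon, seven bonds along the chain from a carbonyl carbon. Ethyl placed two bonds along the chain from a carbonyl carbon gave a number 49 percentage points lower from compound 1 to compound 2 (beyond the scatter), whereas propyl placed four bonds along gave a number 39 percentage points higher from compound 2 to compound 3 (beyond the scatter). These large steps point in opposite directions, so no clear direction can be expected here. The expected result is a number 4 percentage points lower from compound 3 to compound 4 (within the scatter). Compound 4 is estimated at 38%, within an expected range of 12% to 60%.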

Compound 4, percent growth inhibition at one concentration: 42%
Compound 4: middle estimate off by 4 percentage points, on the low side; low and high end bracket the measured number.
By their numbers in this assay, from the lowest: compound 2; then compounds 3, 4 and 1 (each within the scatter of the next).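

Ethyl placed seven bonds along the chain from a carbonyl carbon gives no change at the digits printed from compound 3 to compound 4 (within the scatter) in this assay, so this position accepts the change, unlike the site two bonds along: the same change on two cores in this assay, a number 49 percentage points lower (beyond the scatter) from compound 1 to compound 2 and no change at the digits printed (within the scatter) from compound 3 to compound 4, 49 percentage points apart, beyond the scatter of two such steps The low value now stands out as a single dip rather than a trend with chain size, with a number 39 percentage points higher from compound 2 to compound 4 (beyond the scatter) but a number 10 percentage points lower from compound 1 to compound 4 (within the scatter). Adding a chain therefore has no single effect here, and its outcome depends on the starting compound: the same change on two cores in this assay, a number 10 percentage points lower (within the scatter) from compound 1 to compound 3 and a number 39 percentage points higher (beyond the scatter) from compound 2 to compound 4, 49 percentage points apart, beyond the scatter of two such steps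

The compounds shown leave open whether a longer chain would hold this level in this assay. They also leave open how an amine or a carboxylic acid at the chain end would read.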